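This account rests on a few compounds, and the source may have more. Where it says the series, first, only, none or still open, it means among the compounds named here.

Measured so far:
- compound 1, `Cc1ccc2nc(NC(=O)c3cn(-c4ccccc4)nc3-c3ccc(F)cc3)sc2c1`: in a functional assay on PC-3 cells (Homo sapiens) for cytotoxicity, read by MTT assay, with a stated time of 72 h (a higher number here means a weaker inhibitor, a lower number a stronger inhibitor), compound 1 gives 20500 nM
- compound 2, `COc1ccc(-c2nn(-c3ccccc3)cc2C(=O)Nc2nc3ccc(OC)cc3s2)cc1`: in this assay compound 2 gives 13500 nM

Compound 2 carries the lowest of the two numbers, but its nearest neighbour, compound 1, sits only a small distance away, within the usual scatter of repeated measurements, so no order between the two can be read from these values. Within the data shown here, no pair differing in a single place has been measured, so the series gives no calibrated step.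

Compound 3, `COc1ccc(-c2nn(-c3ccccc3)cc2C(=O)Nc2nc3ccc(C)cc3s2)cc1`, has not yet been measured. It differs from compound 2 by methyl in place of methoxy on an aromatic carbon; read one bond further out, 6-methoxy-1,3-benzothiazol-2-yl becomes 6-methyl-1,3-benzothiazol-2-yl. Compound 1, which also carries the methyl on that fused ring, differs from compound 2 in a second place as well, so its value cannot be taken as a direct guide. With nothing measured on this exact change, the expected step of a 1.3-fold higher number from compound 2 to compound 3 (0.10 log units; within the scatter) is small, most likely not beyond the scatter in either direction. Compound 3 is accordingly expected at about 17000 nM, with a plausible range from 7000 nM to 40000 nM.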

Compound 3, half-maximal inhibitory concentration: 15900 nM
Compound 3: the middle estimate sits 1.1-fold (0.03 log units) above what was measured; the range from low to high includes it.
By their numbers in this assay, from the lowest: compounds 2, 3 and 1 (each within the scatter of the next).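

Read in (this assay), the series now has its first calibrated step: methyl in place of methoxy on this aromatic carbon, with 6-methoxy-1,3-benzothiazol-2-yl becoming 6-methyl-1,3-benzothiazol-2-yl, stays within the scatter (a 1.2-fold higher number from compound 2 to compound 3 (0.07 log units; within the scatter)), so this exchange cannot be told apart from repeat measurement. A second pair, with the 6-methyl-1,3-benzothiazol-2-yl group held in common, gives a step in another place, methoxy in place of fluoro on an aromatic carbon, and this too stays within the scatter (a 1.3-fold lower number from compound 1 to compound 3 (0.11 log units; within the scatter)), so neither single change shown separates its pair. Nothing measured alongside these numbers offers an explanation for them.

From the compounds shown here alone, both readings rest on small, uncharged groups, so it remains open whether a primary amine, a carboxylic acid or a longer chain such as butoxy on the same aromatic carbon would move the number beyond the scatter. Also open is whether a hydroxy group or a chlorine atom in the place of the fluoro or methoxy group would do so, since the two steps shown cover only one exchange at each place.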